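The compounds below may be only part of what the source reports. "The series", "measured", "known", "first", "only" and "open" are said of these compounds alone.

Of the compounds shown here, two from this series have been measured in a functional assay on PC-3 cells (Homo sapiens) for antiproliferative activity, read by MTT assay, with a stated time of 48 h; on this read-out lower numbers stand for stronger inhibition and higher numbers for weaker inhibition. Compound 1 `COc1ccc(-n2cc(COc3ccc(/C=C/C(C)=O)cc3OC)nn2)cc1` gives 2010 nM, and compound 2 `COc1cc(/C=C/C(C)=O)ccc1OCc1cn(-c2ccc(C)cc2)nn1` gives 58100 nM, so compound 2 stands as the higher of the two numbers. Within the data shown here, the single step between them, a 29-fold higher number from compound 1 to compound 2 (1.46 log units; beyond the scatter), shows that the group on this aromatic carbon carries real weight for the read-out.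

Compound 3 `CCOC(=O)c1ccc(-n2cc(COc3ccc(/C=C/C(C)=O)cc3OC)nn2)cc1` differs from compound 2 by ethoxycarbonyl in place of methyl on an aromatic carbon, the new group sitting para to a large group on the same ring. Among the measured compounds shown here, no measured step covers an ethoxycarbonyl at this position, so the only guidance is the size of the methoxy-to-methyl step, which went beyond the scatter. Since compound 1 with its methoxy group gives 2010 nM while compound 2 with methyl gives 58100 nM, a group that again carries acceptors is expected to move the number back toward the lower value, though by how much remains uncertain. The step is estimated as a 7.3-fold lower number from compound 2 to compound 3 (0.86 log units; beyond the scatter), and compound 3 is expected to give about 8000 nM, in a range from 1500 nM to 40000 nM.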

Compound 3, half-maximal inhibitory concentration: 59200 nM
For compound 3 the middle estimate is 7.4-fold (0.87 log units) below the measured one; the measured number lies above the stated range.
By their numbers in this assay, from the lowest: compound 1; then compounds 2 and 3 (each within the scatter of the next).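

In this assay, putting ethoxycarbonyl in place of methyl on the aromatic carbon para to a large group gives a 1.0-fold higher number from compound 2 to compound 3 (0.01 log units; within the scatter) and so leaves the read-out where methyl had it, even though ethoxycarbonyl brings hydrogen-bond acceptors and methyl has none. Against methoxy, the same ethoxycarbonyl gives a 29-fold higher number from compound 1 to compound 3 (1.47 log units; beyond the scatter) and so matches the large step already seen with methyl, which means that among these three groups only methoxy, in compound 1, goes with the lower number, while two groups as different in size as methyl and ethoxycarbonyl cannot be told apart here. No measurement is at hand that could explain why methoxy stands apart from the other two groups at this position.

With only three groups at this position, the compounds shown leave open whether the lower number belongs to methoxy alone or would also be reached with a hydroxyl, an ethoxy or a dimethylamino group. They also leave open whether a fluorine or a carboxylic acid on the same carbon would stay with compound 2 and compound 3 or move toward compound 1.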